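This account rests on a few compounds, and the source may have more. Where it says the series, first, only, none or still open, it means among the compounds named here.

Compounds measured in a functional assay on CHO cells for agonist activity at Alpha-1A adrenergic receptor (Homo sapiens), read by FLIPR and calcium flux; on this read-out higher numbers stand for larger maximal responses and lower numbers for smaller maximal responses:
compound 1 `COc1c(Cl)ccc2c1CCC2c1ncc[nH]1` gives 24%
compound 2 `Clc1ccc2c(c1-c1ccn[nH]1)CCC2c1ncc[nH]1` gives 40%

Compound 2 stands highest of the two numbers; the nearest is compound 1, the step between them being a number 16 percentage points higher from compound 1 to compound 2 (beyond the scatter). That step, the only one measured, exchanges methoxy for 1H-pyrazol-5-yl on an aromatic carbon and does not touch the position changed here. Compound 3 `c1cc(-c2ccn[nH]2)c2c(c1)C(c1ncc[nH]1)CC2` differs from compound 2 by hydrogen in place of chloro on an aromatic carbon: the chloro leaves and a hydrogen atom enters on an aromatic carbon of the six-membered aromatic ring of carbon only, ortho to the 1H-pyrazol-5-yl group. Among the compounds with values here, no measured step concerns the chloro or this position, so no direction can be read from the series; the working expectation for this assay is a step of a number 5 percentage points lower from compound 2 to compound 3 (within the scatter), within the scatter, with a wide range around it. Compound 3 is accordingly expected to give 35%, estimated between 15% and 55%.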

Compound 3, largest response reached (Emax), in percent of the reference or control that the assay uses: 83%
For compound 3 the middle estimate is 48 percentage points below the measured one; the measured number lies above the stated range.
By their numbers in this assay, from the lowest: compound 1; then compound 2; then compound 3.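

In this assay, the aromatic carbon ortho to the 1H-pyrazol-5-yl group proves to be a sensitive position: hydrogen in place of chloro gives a number 43 percentage points higher from compound 2 to compound 3 (beyond the scatter). The earlier step, a number 16 percentage points higher from compound 1 to compound 2 (beyond the scatter), changed a different position and is the smaller of the two, so the chloro position carries the largest change seen in this short series. Nothing available here explains the size of this step.

Open, from the compounds shown here alone, is whether a fluorine atom, a methyl group or an amine on this carbon would give a number nearer that of compound 2 or that of compound 3. Also open, going by these compounds, is whether removing the chloro gives a step of similar size when methoxy, rather than 1H-pyrazol-5-yl, sits on the neighbouring aromatic carbon.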